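This account rests on a few compounds, and the source may have more. Where it says the series, first, only, none or still open, it means among the compounds named here.

Working notes on the series.

Compound 1 `C=CCOc1ccc(C(=O)Nc2cccc(Cl)n2)cc1` is the parent of this set. In an in vitro assay on HEK-tsA201 cells for antagonist activity at Neuronal acetylcholine receptor; alpha3/beta4 (Homo sapiens), read by fluorescence and calcium flux (a lower number here means a stronger inhibitor, a higher number a weaker inhibitor), compound 1 gives only a limit, > 100000 nM, not a number. Compound 2 `CCCOc1ccc(C(=O)Nc2cccc(Cl)n2)cc1` likewise reaches only a limit in this assay, > 100000 nM. Compound 3 `CCCOc1ccc(C(=O)Nc2cccc(Nc3cccc(F)c3)n2)cc1` also returns a limit in this assay, > 100000 nM. As a result, the chain-end change from compound 1 to compound 2 gives a step that the two limits leave unreadable from compound 1 to compound 2, and the replacement of chloro by (3-fluorophenyl)amino from compound 2 to compound 3 gives a step that the two limits leave unreadable from compound 2 to compound 3. The one common finding is the limit of > 100000 nM in this assay, at which 3 of the 3 values shown sit.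

Compound 4 `C=CCOc1ccc(C(=O)Nc2cccc(NCCCC)n2)cc1` differs from compound 1 by butylamino in place of chloro on an aromatic carbon. Within the data shown here, the step from compound 2 to compound 3 is the nearest comparison, an amino substituent entering in place of chloro on the same ring carbon, but it is unreadable, and no measured step in the set carries a readable size. The expectation for compound 4 is therefore that it stays at the same limit, with the step from compound 1 to compound 4 estimated as a number no higher from compound 1 to compound 4 (the limit leaves the size open). The estimate for compound 4 in this assay is 100000 nM, in the range 30000 nM to 500000 nM, most probably reported as a limit only.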

Compound 4, half-maximal inhibitory concentration: 19200 nM
For compound 4 the middle estimate is 5.2-fold (0.72 log units) above the measured one; measured number outside the range, below it.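

Butylamino in place of chloro on the aromatic carbon next to the ring nitrogen gives an at least 5.2-fold lower number from compound 1 to compound 4 (0.71 log units; beyond the scatter) in this assay, and the size of this step remains open at its upper end. Among these compounds, this shows that a change at this carbon can bring a value within the measured range, whereas the earlier steps cannot be read. An amino group at this carbon is not enough on its own, since compound 3, which carries (3-fluorophenyl)amino there, gives only a limit, > 100000 nM, and compound 4 alone leaves the shared limit: the limit of > 100000 nM in this assay, at which 3 of the 4 values shown sit.

The compounds shown leave open whether a shorter chain such as ethylamino, a longer chain such as hexylamino or a cyclic amine such as piperidine would do better or worse at this carbon. They also leave open whether butylamino would give a similar result with the propoxy group of compound 2.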